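This account rests on a few compounds, and the source may have more. Where it says the series, first, only, none or still open, it means among the compounds named here.

Of the compounds shown here, two sharing one core have been tested in an ADME assay on L6 cells (Rattus norvegicus) for cytotoxicity, read by microscopy and resazurin assay, with a stated time of 72 h; a lower number here means that less compound is needed, a higher number that more compound is needed for the effect. Compound 1 `O=C1/C(=C/c2ccn(-c3ccccc3C(F)(F)F)c2)S/C(=N\c2ccccc2)N1C1CCCCC1` gives a reading in this assay that is only a limit of the assay, > 180000 nM. Compound 2 `O=C1/C(=C/c2ccn(Cc3ccccc3)c2)S/C(=N\c2ccccc2)N1C1CCCCC1` likewise gives only a limit in this assay, > 200000 nM. The step between them, a step that the two limits leave unreadable from compound 1 to compound 2, cannot be read, since both values sit at limits, as the limit of > 180000 nM in this assay, at which 1 of the 2 values shown sits, and the limit of > 200000 nM in this assay, at which 1 of the 2 values shown sits, state. Compound 3 `CN1C(=O)/C(=C/c2ccn(Cc3ccccc3)c2)S/C1=N\c1ccccc1` differs from compound 2 by methyl in place of cyclohexyl on an amide-type nitrogen in a ring. Among the measured compounds shown here, no measured step touches this position, and there is no direct guide to the size of the change; the only evidence is that compound 2 gave a limit. Compound 3 is expected to stay close to that, with an expected step of a number no higher from compound 2 to compound 3 (the limit leaves the size open) that does not go beyond the scatter. The estimate for compound 3 in this assay is 200000 nM, ranging from 60000 nM to 400000 nM, most likely reported again as a limit.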

Compound 3, half-maximal effective concentration: > 240000 nM
Compound 3: only a limit was reported; the forecaster's own chance of this, stated with the estimate: 75%; middle value at least 1.2-fold (0.07 log units) from the limit.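

Compound 3 also gives only a limit of the assay, > 240000 nM. Since compound 2 sits at a limit too, the step between compound 2 and compound 3 cannot be read. What concentration of any of these compounds would reach the effect in this assay stays open.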